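Butyl for phenylsulfanyl on the shared core: expected inhibition

A few compounds are considered here, and "the series" means these few. Any claim that something is new, unique, unknown or untested is made for them only; others in the source may bear on it.

Three compounds of this series have been run in a functional assay on the whole organism (Pleural cavity) for inhibition, with Rattus norvegicus as the target, at a dose of 25 mg/kg; a higher number here means more inhibition at the dose given (going by the name of the read-out), a lower number less inhibition. Compound 1 `CC1(C)C(=O)N(c2ccc(Cl)cc2Cl)c2ncccc21` gives 8%, compound 3 `CC1(C)C(=O)N(c2cccc(C(F)(F)F)c2)c2ncccc21` gives 10%, and compound 2 `CC1(Sc2ccccc2)C(=O)N(c2ccccc2)c2ncccc21` gives 0%. The gaps from compound 2 to compound 1 and from compound 2 to compound 3 both lie within the usual scatter of repeated measurements, so the three numbers cannot be told apart, and all three sit near the bottom of the percentage scale in this assay.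

Compound 4 `CCCCC1(C)C(=O)N(c2ccccc2)c2ncccc21` has not yet been measured. It differs from compound 2 in one place: butyl in place of phenylsulfanyl on a saturated ring carbon. Among the measured compounds shown here, no step between two measured compounds bears on this particular exchange, so the expectation rests on the three numbers above alone.

Since every measured member of the series, whatever the group on that saturated ring carbon or on the ring nitrogen, gives a low number in this assay, no step beyond the scatter is expected for compound 4 in either direction; the estimated step from compound 2 to compound 4 is a number 5 percentage points higher from compound 2 to compound 4 (within the scatter). On that basis compound 4 is expected to give about 5% in this assay, with a range from 0% to 20%.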

Compound 4, a percentage reported as inhibition, in the whole organism at one dose (the size of the read-out at that dose, not a potency): 5%
Estimate against measurement, compound 4: no gap at the digits printed, and the stated range covers the measured number.
By their numbers in this assay, from the lowest: compounds 2, 4, 1 and 3 (each within the scatter of the next).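

In this assay the saturated ring carbon now has its first direct reading for one exchange: butyl in place of phenylsulfanyl gives a number 5 percentage points higher from compound 2 to compound 4 (within the scatter) with the ring nitrogen substituent held as phenyl. Within this pair, the group carrying the aromatic ring and the sulfur and the open four-carbon chain cannot be told apart, so this exchange shows neither of the two groups to be required for a reading at this level. Nothing at hand bears on why the two groups read alike.

The compounds shown leave open whether any group on this carbon can give a step beyond the scatter, for instance a primary amine, a carboxylic acid or a chain longer than butyl. They also leave open whether compound 2 and compound 4 would remain indistinguishable at another dose, since the pair is read at a single dose, close to the bottom of the percentage scale.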